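The source may report more compounds than this note shows. Statements on the series, on what has been measured and on what is new or still open speak of the compounds shown alone.

Compound 1 `CN(C)C(=O)c1cccnc1NCCCN1CCN(c2ccccc2O)CC1` and compound 2 `CN(C)C(=O)c1cccnc1NCCCN1CCN(c2ccccc2C2CC2)CC1` share one core and differ at a single aromatic carbon, where compound 1 carries hydroxy and compound 2 carries cyclopropyl. In a functional assay for antagonist activity at Alpha-1A adrenergic receptor (Oryctolagus cuniculus) (on this read-out higher numbers stand for weaker binding and lower numbers for tighter binding), compound 1 gives 5.01 nM and compound 2 gives 0.631 nM. For the measured compounds named here, that step, a 7.9-fold lower number from compound 1 to compound 2 (0.90 log units; beyond the scatter), is the only comparison measured so far; it leaves compound 2 with the lower of the two numbers in this assay, and compound 1 is its only neighbour.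

Compound 3 `CN(C)C(=O)c1cccnc1NCCCN1CCN(c2ccccc2C(F)(F)F)CC1` is not yet measured. Relative to compound 2 the change is trifluoromethyl in place of cyclopropyl on an aromatic carbon, at the same aromatic carbon, ortho to a large group, that was varied between compound 1 and compound 2. Going by the values given here, no measured step covers this exchange directly. Among the compounds with values here, the one step that bears on the position, a 7.9-fold lower number from compound 1 to compound 2 (0.90 log units; beyond the scatter), shows that putting one three-membered non-aromatic ring of carbon only in place of hydroxy gave a modest gain, but it says nothing about trifluoromethyl there. For compound 3 a step close to compound 2 is therefore expected, a 1.6-fold higher number from compound 2 to compound 3 (0.20 log units; within the scatter), near the scatter, with a slightly weaker result somewhat more likely than a further gain. The estimate for compound 3 in this assay is 1 nM, with a range from 0.3 nM to 3.2 nM.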

Compound 3, dissociation constant: 12.6 nM
Compound 3: middle estimate off by 13-fold (1.10 log units), on the low side; measured number outside the range, above it.
By their numbers in this assay, from the lowest: compound 2; then compound 1; then compound 3.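

In this assay this aromatic carbon proves sharply sensitive to which group it carries, even between two groups counted with no hydrogen-bond donors or acceptors: trifluoromethyl in place of cyclopropyl gives a 20-fold higher number from compound 2 to compound 3 (1.30 log units; beyond the scatter). Trifluoromethyl also falls behind hydroxy, with a 2.5-fold higher number from compound 1 to compound 3 (0.40 log units; beyond the scatter), so the number does not simply improve on moving away from hydroxy; the outcome depends on which group replaces it, and cyclopropyl alone among the three gives a gain over hydroxy. Nothing in the available data explains either step.

As far as these compounds go, with a single example of each group, it remains open whether the low number of compound 2 goes with the three-membered ring itself or with a group of carbon only; an isopropyl group, a cyclobutyl ring and a methoxy group at the same aromatic carbon would help separate these readings. Also open, from the compounds shown here alone, is whether the order of cyclopropyl, hydroxy and trifluoromethyl holds when other parts of the shared core change.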